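A Second Hydroxy Group on the Hydrazone Ring

The source may hold more compounds than are shown below. What is called first, only, known or untested is meant among the compounds shown, and "the series" means these compounds.

Measured compounds:
compound 1, `O=[N+]([O-])c1ccccc1CSc1nnc(-c2ccncc2)n1-c1ccccc1`: > 50000 nM
compound 2, `O=C(CSc1nnc(-c2ccncc2)n1-c1ccccc1)N/N=C/c1ccc(O)cc1`: > 50000 nM

Both compounds were tested in a functional assay on HepG2 cells (Homo sapiens) for inhibition, read by MTT assay, with a stated time of 48 h; a higher number here means a weaker inhibitor, a lower number a stronger inhibitor. In this assay compound 1 gives > 50000 nM, which is a limit of the assay and not a measured number. In this assay compound 2 likewise gives > 50000 nM, again a limit rather than a number. Going by the values given here, compound 2 therefore stands at the edge of what the assay can report, as the limit of > 50000 nM in this assay, at which 2 of the 2 values shown sit, shows, and since both known compounds sit there, no step between measured compounds can be drawn.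

Compound 3, `O=C(CSc1nnc(-c2ccncc2)n1-c1ccccc1)N/N=C/c1ccc(O)c(O)c1`, differs from compound 2 by hydroxy in place of hydrogen on an aromatic carbon. Without any measured step to build on, the expectation for compound 3 rests only on the two limits already seen. The step expected in this assay is a step that the limit leaves unreadable from compound 2 to compound 3, that is, none beyond the usual scatter, and the most likely outcome is that compound 3 again returns only a limit. The estimate for compound 3 in this assay is 60000 nM, with a range from 15000 nM to 250000 nM.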

Compound 3, half-maximal inhibitory concentration: 16900 nM
For compound 3 the middle estimate is 3.6-fold (0.55 log units) above the measured one; low and high end bracket the measured number.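

Going by these compounds alone, compound 3 is the first compound here to give a real number rather than a limit: in this assay, compound 3 gives 16900 nM. This shows that the ring carrying the hydroxy group can respond to change, since going from 4-hydroxyphenyl to 3,4-dihydroxyphenyl, with the new hydroxy group ortho to the existing one, gives an at least 2.9-fold lower number from compound 2 to compound 3 (0.47 log units; beyond the scatter). The true size of this step cannot be read, only its smallest possible size, because the starting point is a limit of the assay and not a number: the limit of > 50000 nM in this assay, at which 2 of the 3 values shown sit.

The compounds shown leave open whether the gain needs a hydroxy group at this place at all, or whether a methoxy group, an amine or a fluorine atom in the same spot would serve equally well. They also leave open whether the hydroxy group must sit ortho to the first one, and whether the same change would give a similar step in this assay on a compound with a different core.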